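The source may hold more compounds than are shown below. What is called first, only, known or untested is meant among the compounds shown, and "the series" means these compounds.

Measured in a functional assay on A549 cells (Homo sapiens) for cytotoxicity; a higher number here means that more compound is needed for the effect, a lower number that less compound is needed:
- Compound 1 `COc1cc(/C=C\c2ccc(C(C)(C)C)cc2)cc(OC)c1OC`: 1.02 uM
- Compound 2 `COc1ccc(/C=C\c2cc(OC)c(OC(C)=O)c(OC)c2)cc1`: 21.5 uM
- Compound 3 `COc1cc(/C=C/c2ccc(C(C)(C)C)cc2)cc(OC)c1OC`: > 25 uM (a limit of the assay, not a number)

Compound 1 holds the lower of the two actual numbers in this assay, and compound 2 follows at 21.5 uM. The next structure is compound 4 `CCCOc1ccc(/C=C\c2cc(OC)c(OC)c(OC)c2)cc1`, which has not yet been measured. It departs from compound 1 by one change: propoxy in place of tert-butyl on an aromatic carbon. Propoxy takes the place of tert-butyl on an aromatic carbon, and the double bond stays drawn Z.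

For the measured compounds named here, only one measured step exists, and it does not touch this group: an at least 24-fold higher number from compound 1 to compound 3 (1.38 log units; beyond the scatter). That large step goes with the fact that compounds 1 and 3 differ only in the configuration as drawn, so it says nothing direct about the swap, although compound 4 keeps the configuration of compound 1. Compound 2 is also drawn Z, yet it reads 21.5 uM, so the Z drawing alone does not guarantee a number as low as that of compound 1. No measured step sizes the exchange itself, so a moderate move towards a higher number is expected, with wide uncertainty. The expected change is a 3.9-fold higher number from compound 1 to compound 4 (0.59 log units; beyond the scatter). For compound 4 the estimate is 4 uM, within an expected range of 0.8 uM to 20 uM.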

Compound 4, concentration for half-maximal effect: 3.9 uM
Beside the measured number, compound 4's estimate is 1.0-fold (0.01 log units) above it, and the stated range covers the measured number.
By their numbers in this assay, from the lowest: compound 1; then compound 4; then compound 2. At a limit, above all of these: compound 3.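

In this assay, for the compounds shown here, exchanging tert-butyl for propoxy on an aromatic carbon of a six-membered aromatic ring of carbon only, para to a large group, gives a 3.8-fold higher number from compound 1 to compound 4 (0.58 log units; beyond the scatter), the first measured step at this position. The two groups both have 4 heavy atoms, but propoxy brings an oxygen and a hydrogen-bond acceptor, and compound 4 still gives a real number of 3.9 uM in the Z series. This modest step stands against the large step for the double bond, an at least 24-fold higher number from compound 1 to compound 3 (1.38 log units; beyond the scatter), which goes with a change in drawn configuration alone: the fact that compounds 1 and 3 differ only in the configuration as drawn

The compounds shown leave open whether the step follows the oxygen or the chain, as neither a plain propyl group nor a longer chain such as butoxy appears at this place. They also leave open how an amine or a carboxylic acid would read there, and whether the E form of compound 4 would fall as far as compound 3 did.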